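Trading a Bicyclic Group for a Chloropyrazole

The compounds below may be only part of what the source reports. "The series", "measured", "known", "first", "only" and "open" are said of these compounds alone.

Compound 1 `C[C@@H]1CN(c2sc(C3COC3)nc2-c2nc3ccccc3[nH]2)CCN1C(=O)Cn1cnc2cccnc21` gives 1150 nM in an assay on blood for inhibition of C-X-C chemokine receptor type 3 (Homo sapiens), with a stated time of 30 min; on this read-out higher numbers stand for weaker inhibition and lower numbers for stronger inhibition; compound 2 `CCOc1ncc(-c2nc(C(F)(F)F)sc2N2CCN(C(=O)Cn3c(=O)oc4ccccc43)[C@H](C)C2)cn1` gives 536 nM in this assay.

Of these two numbers, compound 2 has the lower one, and the gap to compound 1 lies beyond the usual scatter. Compound 3 `CCOc1ncc(-c2nc(C(F)(F)F)sc2N2CCN(C(=O)Cn3cc(Cl)cn3)[C@H](C)C2)cn1` has not yet been measured. It differs from compound 2 by a group of 6 heavy atoms (3 carbon, 2 nitrogen, 1 chlorine; one five-membered aromatic ring with 2 hetero atoms) in place of a group of 10 heavy atoms (7 carbon, 1 nitrogen, 2 oxygen; one five-membered aromatic ring with 2 hetero atoms, one six-membered aromatic ring of carbon only), on a saturated chain carbon bound to a carbonyl carbon. Among the measured compounds shown here, no measured pair shows a change of this kind, so its size cannot be read from the data; a small move toward weaker inhibition, or none beyond the scatter, seems most plausible. Compound 3 is expected to give about 750 nM, within a range from 250 nM to 2200 nM. The expected step is a 1.4-fold higher number from compound 2 to compound 3 (0.15 log units; within the scatter).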

Compound 3, half-maximal inhibitory concentration: 245 nM
Compound 3: middle estimate off by 3.1-fold (0.49 log units), on the high side, and the stated range ends above it.
By their numbers in this assay, from the lowest: compound 3; then compound 2; then compound 1.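

At the saturated chain carbon bound to a carbonyl carbon, the larger two-ring group is not needed: with 4-chloro-1H-pyrazol-1-yl in its place, this assay gives a 2.2-fold lower number from compound 2 to compound 3 (0.34 log units; beyond the scatter). A single five-membered aromatic ring therefore serves here, and inhibition grows stronger rather than weaker. No measurement shown explains this gain. What remains open is whether the chlorine matters, since the compounds shown do not tell how a pyrazole carrying a methyl group or a nitrile instead, or an unsubstituted pyrazole, would compare.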